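The compounds below may be only part of what the source reports. "The series", "measured", "known", "first", "only" and "open" are said of these compounds alone.

Compound 1 `O=C(Nc1cccc(Cl)c1)O/N=C(\C1CCCCC1)C(Cn1ccnc1)C1CCCCC1` gives 10.8 nM; 8.78 nM; 1000 nM (3 entries) in an assay on isolated protein for displacement of a labelled ligand from metabotropic glutamate receptor 5 (Rattus norvegicus); on this read-out lower numbers stand for stronger inhibition and higher numbers for weaker inhibition. Compound 2 `O=C(Nc1cccc(Cl)c1)O/N=C(\C1CCCCC1)C(Cc1cc[nH]c1)C1CCCCC1`, which carries a pyrrolyl group on the saturated chain carbon, gives 16.1 nM in this assay; that is the only number shown for it, and one further entry carries no single number. Compound 3 `CN(C)c1ccc(CC(/C(=N/OC(=O)Nc2cccc(Cl)c2)C2CCCCC2)C2CCCCC2)cc1` differs from compound 2 by 4-(dimethylamino)phenyl in place of 1H-pyrrol-3-yl on a saturated chain carbon, two bonds along the chain from a carbon with a double bond to nitrogen and a saturated ring carbon, a 4-(dimethylamino)phenyl in place of 1H-pyrrol-3-yl on a saturated chain carbon, two bonds along the chain from a carbon with a double bond to nitrogen and a saturated ring carbon. For the measured compounds named here, no measured step guides this change, so the expected step of a 2.2-fold higher number from compound 2 to compound 3 (0.34 log units; beyond the scatter) is modest, toward weaker binding. Compound 3 is therefore estimated at 35 nM, between 8 nM and 160 nM.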

Compound 3, inhibition constant: > 1000 nM
Compound 3 gave a limit, no number (the forecaster's own chance of this, stated with the estimate: 5%); middle value at least 28-fold (1.45 log units) from the limit.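

Compound 3 gives > 1000 nM in this assay, which is a limit of the assay and not a number. For the compounds shown here, this is the first step read at this saturated chain carbon: 4-(dimethylamino)phenyl in place of 1H-pyrrol-3-yl gives an at least 62-fold higher number from compound 2 to compound 3 (1.79 log units; beyond the scatter). The position therefore does not accept every aromatic group equally.

The compounds shown do not separate the carbon-only ring from its dimethylamino group, so an unsubstituted phenyl group or a 4-methoxyphenyl group remains an open case here. The full size of the step also stays open, because the read-out gives only a limit at this height: the limit of > 1000 nM in this assay, at which 1 of the 3 values shown sits.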